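The source may report more compounds than this note shows. Statements on the series, on what has been measured and on what is new or still open speak of the compounds shown alone.

In an assay on membranes from CHO cells for displacement of a labelled ligand from adenosine receptor A1 (Homo sapiens), read by scintillation counting, with a stated time of 60 min, tested at 1 uM (a lower number here means less inhibition, a higher number more inhibition at the concentration tested (going by the name of the read-out)), compound 2 `CCNC(=O)C1=C(C)NC(=O)NC1c1ccsc1` gives 3%. Compound 1 `CCNC(=O)C1=C(C)NC(=O)NC1c1cccs1` gives 1%, and compound 3 `CCN(CC)C(=O)C1=C(C)NC(=O)NC1c1ccsc1` gives 11%; the step of a number 2 percentage points higher from compound 1 to compound 2 (within the scatter) and the step of a number 8 percentage points higher from compound 2 to compound 3 (within the scatter) both lie within the scatter, so these three compounds cannot be told apart on the numbers shown. Compound 4 `CC1=C(c2ncc(C)o2)C(c2ccsc2)NC(=O)N1` differs from compound 2 by 5-methyl-1,3-oxazol-2-yl in place of ethylcarbamoyl on a double-bonded ring carbon. Within the data shown here, no measured step exchanges the whole ethylcarbamoyl group for an aromatic ring; the closest is a number 8 percentage points higher from compound 2 to compound 3 (within the scatter), which alters only the substituent on the amide-type nitrogen and stays within the scatter. With no firmer guide, the expected step of a number 2 percentage points higher from compound 2 to compound 4 (within the scatter) is none beyond the scatter. Compound 4 is therefore estimated to give 5%, within a range from -8% to 20%.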

Compound 4, a percentage reported as inhibition, at one concentration (the size of the read-out at that concentration, not a potency): 34%
The estimate for compound 4 lay 29 percentage points below the measured number, and the stated range ends below it.
By their numbers in this assay, from the lowest: compounds 1, 2 and 3 (each within the scatter of the next); then compound 4.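

In this assay, among these compounds, replacing the ethylcarbamoyl group on this double-bonded ring carbon gives a number 31 percentage points higher from compound 2 to compound 4 (beyond the scatter), the only step here beyond the scatter. The number at this position can therefore shift when the whole group is exchanged for 5-methyl-1,3-oxazol-2-yl, which neither the change of thiophene attachment nor the added ethyl on the amide-type nitrogen showed. Nothing available explains the shift.

Still open, on these data alone, is whether the methyl on the new ring matters, and whether a plain phenyl ring or a carboxylic acid at this ring carbon would give a similar number.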